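The source may report more compounds than this note shows. Statements on the series, on what has been measured and on what is new or still open speak of the compounds shown alone.

Working notes on the series. Compound 1 `CCOC(=O)c1cnc2n(c1=O)C(C)CC/C2=N\Nc1cccc(C(=O)O)c1` in a functional assay (mast cells) for inhibition, with Rattus norvegicus as the target (on this read-out higher numbers stand for an effect only at larger amounts of compound and lower numbers for an effect already at smaller amounts), gives 740000 nM. Compound 3 `C[C@H]1CC/C(=N\Nc2ccc(O)cc2)c2ncc(C(=O)O)c(=O)n21` gives 26200 nM in this assay. Compound 2 `CC1CC/C(=N\Nc2ccccc2F)c2ncc(C(=O)O)c(=O)n21` gives 1200 nM, the lowest of the three numbers; its gaps to compound 3 and to compound 1 both lie beyond the scatter, so compound 2 stands as the most potent of the measured set. Compound 4 `Cc1cccc(N/N=C2\CCC(C)n3c2ncc(C(=O)O)c3=O)c1` is not yet measured. Relative to compound 2 it carries 3-methylphenyl in place of 2-fluorophenyl on an amine nitrogen. Among the compounds with values here, no measured pair shows this change on its own, so the step to compound 4 rests on expectation alone: a moderate rise in the number, a 2.5-fold higher number from compound 2 to compound 4 (0.40 log units; beyond the scatter), is expected. Compound 4 is estimated at 3000 nM, within the range 600 nM to 15000 nM.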

Compound 4, half-maximal effective concentration: 72900 nM
Estimate against measurement, compound 4: 24-fold (1.39 log units) below; the whole stated range lies below it.
By their numbers in this assay, from the lowest: compound 2; then compound 3; then compound 4; then compound 1.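

Within the data shown here, the first single-place step falls at this position: in this assay, 3-methylphenyl in place of 2-fluorophenyl on an amine nitrogen gives a 61-fold higher number from compound 2 to compound 4 (1.78 log units; beyond the scatter), so the number here depends strongly on the aryl group carried. The two groups share one six-membered aromatic ring of carbon only and no net charge, yet the step is large. Nothing available accounts for its size.

Still open, from the compounds shown here alone, is whether the step follows from the substituent or from where it sits on the ring. A 2-methylphenyl or a 3-fluorophenyl group on the same amine nitrogen would separate the two.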